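Replacing 4-sulfamoylphenyl with 3-nitrophenyl

A few compounds are considered here, and "the series" means these few. Any claim that something is new, unique, unknown or untested is made for them only; others in the source may bear on it.

Compound 1 `Cc1cc(Nc2cc(N3CCN(C)CC3)nc(Nc3ccc(S(N)(=O)=O)cc3)n2)n[nH]1`: 15900 nM
Compound 2 `COc1cccc(Nc2nc(Nc3cc(C)[nH]n3)cc(N3CCN(C)CC3)n2)c1`: 11300 nM

For the measured compounds named here, in a functional assay on SK-BR-3 cells (Homo sapiens) for antiproliferative activity, read by CCK-8 assay, with a stated time of 72 h (a higher number here means a weaker inhibitor, a lower number a stronger inhibitor), compound 1 stands level with compound 2, the only other measured compound, with no real gap between them. Compound 3 `Cc1cc(Nc2cc(N3CCN(C)CC3)nc(Nc3cccc([N+](=O)[O-])c3)n2)n[nH]1` has not been measured. It differs from compound 1 at one place: 3-nitrophenyl in place of 4-sulfamoylphenyl on a nitrogen on an aromatic ring. Going by the values given here, the one measured step at that place, a 1.4-fold lower number from compound 1 to compound 2 (0.15 log units; within the scatter), put 3-methoxyphenyl in place of 4-sulfamoylphenyl. On that single step, no change beyond the scatter is expected in this assay here either. The expected step is a 1.3-fold lower number from compound 1 to compound 3 (0.12 log units; within the scatter). For compound 3 the estimate is 12000 nM, with an expected range from 4500 nM to 30000 nM.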

Compound 3, half-maximal inhibitory concentration: 2180 nM
Compound 3: middle estimate off by 5.5-fold (0.74 log units), on the high side; measured number below the stated range.
By their numbers in this assay, from the lowest: compound 3; then compounds 2 and 1 (each within the scatter of the next).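

The group on this nitrogen can change the number in this assay after all: 3-nitrophenyl brings a real gain over 4-sulfamoylphenyl (a 7.3-fold lower number from compound 1 to compound 3 (0.86 log units; beyond the scatter)), whereas 3-methoxyphenyl brought no change beyond the scatter. Swapping only the group on the phenyl ring also matters, with nitro in place of methoxy (a 5.2-fold lower number from compound 2 to compound 3 (0.71 log units; beyond the scatter)). Nothing available accounts for this gain. As far as these compounds go, what an amine or a carboxylic acid in place of the nitro group would do on this ring remains open.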